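A few compounds are considered here, and "the series" means these few. Any claim that something is new, unique, unknown or untested is made for them only; others in the source may bear on it.

Measured so far, in a functional assay on the whole organism for antagonist activity, with Mus musculus as the target, in the maximal electroshock model; on this read-out higher numbers stand for an effect only at larger amounts of compound and lower numbers for an effect already at smaller amounts:

Compound 1 `Cn1c(-c2ccccc2)nnc1[S+](C)[O-]`: compound 1 gives > 100 mg/kg, a limit of the assay.
Compound 2 `Cn1c(-c2ccccc2F)nnc1[S+](C)[O-]`: compound 2 gives > 200 mg/kg, a limit of the assay.
Compound 3 `Cn1nc(-c2ccccc2)nc1S(C)(=O)=O`: compound 3 gives > 200 mg/kg, a limit of the assay.

The change fluoro in place of hydrogen on an aromatic carbon gives a step that the two limits leave unreadable from compound 1 to compound 2; with the limit of > 100 mg/kg in this assay, at which 1 of the 3 values shown sits, and the limit of > 200 mg/kg in this assay, at which 2 of the 3 values shown sit, on either side, its size cannot be read. Compound 4 `Cn1nc(-c2cccc(F)c2)nc1S(C)(=O)=O` is not yet measured and differs from compound 3 by fluoro in place of hydrogen on an aromatic carbon. This is the same kind of change as in the earlier pair, but the place differs: there ortho to a group of 9 heavy atoms, here meta to a large group. The difference between the core of compound 1 and the core of compound 3 is not broken down here.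

In this assay, going by the values given here, the step from compound 3 to compound 4 is expected to be about a step that the limit leaves unreadable from compound 3 to compound 4, since the one measured instance of this change, a step that the two limits leave unreadable from compound 1 to compound 2, gives no readable size. Compound 3 sits at > 200 mg/kg, a limit. Compound 4 is estimated at 300 mg/kg, between 120 mg/kg and 1000 mg/kg, most likely again only a limit.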

Compound 4, dose for half-maximal effect: > 100 mg/kg
Compound 4: no number, only a limit (the forecaster's own chance of this, stated with the estimate: 85%); the middle value is on the limit's open side.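

Going by these compounds alone, compound 3 and compound 4 both give only a limit in this assay, and no step between them can be read. The compounds shown leave open what size, if any, fluoro in place of hydrogen has on this assay.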